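Methanesulfonamido on the Benzyl Ring of a Tetrazole Secretagogue Ligand

The compounds below may be only part of what the source reports. "The series", "measured", "known", "first", "only" and "open" are said of these compounds alone.

The series was tested in an assay on isolated protein for displacement of a labelled ligand from growth hormone secretagogue receptor type 1 (Homo sapiens), with a stated time of 1 h; a lower number here means a stronger inhibitor, a higher number a weaker inhibitor. Compound 1 `CC(C)(N)C(=O)N[C@H](COCc1ccccc1)c1nnnn1CCCc1ccccc1` gives 200 nM in this assay. Compound 2 `CC(C)(N)C(=O)N[C@H](COCc1ccccc1)c1nnn(Cc2ccccc2)n1` carries a benzyl group on the shared core in place of the three-carbon phenyl chain of compound 1. In this assay compound 2 gives 4750 nM and therefore stands at the highest of the two numbers measured, a gap to compound 1 that lies beyond the usual scatter.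

Compound 3 `CC(C)(N)C(=O)N[C@H](COCc1ccccc1)c1nnn(Cc2cccc(NS(C)(=O)=O)c2)n1` has not yet been measured. It differs from compound 2 in one place: methanesulfonamido in place of hydrogen on an aromatic carbon, on an aromatic carbon of a six-membered aromatic ring of carbon only, meta to a large group. Cut one bond further out, the same change reads phenyl to 3-(methanesulfonamido)phenyl. For the measured compounds named here, no measured pair shows this change, so nothing in the data sets its size.

Going by the values given here, with no comparable step available, compound 3 is expected to give about 2500 nM in this assay, within a range of 800 nM to 8000 nM. This estimated step from compound 2 to compound 3, a 1.9-fold lower number from compound 2 to compound 3 (0.28 log units; within the scatter), is a modest gain that may still fall within the scatter.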

Compound 3, inhibition constant: > 5000 nM
Compound 3 gave a limit, no number; the forecaster's own chance of this, stated with the estimate: 5%; at least 2.0-fold (0.30 log units) between middle value and limit.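

Compound 3 returns only a limit in this assay, > 5000 nM, which is a limit of the assay and not a number. For the compounds shown here, this is the first measured pair for methanesulfonamido in place of hydrogen on an aromatic carbon, meta to a large group, and it gives an at least 1.0-fold higher number from compound 2 to compound 3 (0.02 log units; that floor lies within the scatter), so the change brings no sign of the stronger binding that a lower number would show. The pair sets only a floor on the step and no upper bound, so the change cannot be told apart from no change or from a large loss, and the reading for this position is capped: the limit of > 5000 nM in this assay, at which 1 of the 3 values shown sits.

From the compounds shown here alone, whether compound 3 lies close to compound 2 or far beyond it remains open, as does whether another group at this place on the ring, such as an amine or a carboxylic acid, would behave any differently. Going by these compounds, it is also open whether methanesulfonamido would have the same outcome on the phenyl ring of the three-carbon chain of compound 1, where the starting number is lower and a change in either direction could be read.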